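The compounds below may be only part of what the source reports. "The series", "measured", "known", "first", "only" and "open" are said of these compounds alone.

Working notes on the series, first entry in a functional assay on HCT-116 cells (Homo sapiens) for antiproliferative activity, read by MTT assay, with a stated time of 72 h; on this read-out higher numbers stand for weaker inhibition and lower numbers for stronger inhibition.

Three compounds of the shared core have been run so far. Compound 1 `O=C1COc2ccc(-c3cccc(NS(=O)(=O)c4ccc(F)cc4)c3)cc2N1C1CC1` carries a cyclopropyl on the amide-type nitrogen in the ring; in this assay compound 1 gives only a limit, > 40000 nM. Compound 2 `O=C1COc2ccc(-c3cccc(NS(=O)(=O)c4ccc(F)cc4)c3)cc2N1c1ccccc1` differs by phenyl in place of cyclopropyl on that nitrogen; compound 2 likewise gives only a limit, > 40000 nM. The step that the two limits leave unreadable from compound 1 to compound 2 therefore cannot be sized. Compound 3 `Cc1ccc(N2C(=O)COc3ccc(-c4cnc5ccccc5c4)cc32)cc1` replaces the sulfonamide-bearing aryl of the first two with a bicyclic heteroaryl and carries 4-methylphenyl on the ring nitrogen; compound 3 also gives only a limit, > 40000 nM. Compound 3 thus stands nowhere distinguishable from compounds 1 and 2, all three sitting at the same limit (the limit of > 40000 nM in this assay, at which 3 of the 3 values shown sit).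

Compound 4 `O=C1COc2ccc(-c3cnc4ccccc4c3)cc2N1c1ccc(Cl)cc1` is the next member: chloro in place of methyl on an aromatic carbon, on an aromatic carbon of the six-membered carbon-only ring, para to a large group. No measured step bears on a change of this kind, and every step shown is unreadable, so no direction beyond the scatter can be argued. Given that compound 3 sits at the limit > 40000 nM, compound 4 is expected to give about 40000 nM, and the step of a number no higher from compound 3 to compound 4 (the limit leaves the size open) is estimated to be nil within the scatter, with a limit again the most probable outcome.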

Compound 4, half-maximal inhibitory concentration: 36100 nM
Beside the measured number, compound 4's estimate is 1.1-fold (0.04 log units) above it, and the stated range covers the measured number.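

In this assay compound 4 is the first member of the series to give a number and not a limit, with the other compounds all at one limit: the limit of > 40000 nM in this assay, at which 3 of the 4 values shown sit.

On an aromatic carbon of a six-membered aromatic ring of carbon only, para to a large group, chloro in place of methyl gives an at least 1.1-fold lower number from compound 3 to compound 4 (0.04 log units; that floor lies within the scatter). Within the data shown here, this is the first step with a readable floor, but the floor does not establish a change beyond the scatter, and the upper size of the step remains open with only a limit for compound 3.

The other step, on the amide-type nitrogen in the ring, cannot be read, so the series gives no size against which to set this one. Going by these compounds, it also remains open whether an amine or a carboxylic acid in place of chloro on the same ring would give a number clearly beyond the scatter from that of compound 4, and whether 4-chlorophenyl on the ring nitrogen would give a number alongside the sulfonamide-bearing aryl of compound 1 and compound 2.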